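From 4-methylbenzyl to 2-fluorobenzyl in a level series

The compounds below may be only part of what the source reports. "The series", "measured", "known", "first", "only" and "open" are said of these compounds alone.

Measured so far in a functional assay on DU-145 cells (Homo sapiens) for inhibition, read by trypan blue exclusion, with a stated time of 96 h (on this read-out higher numbers stand for weaker inhibition of growth and lower numbers for stronger inhibition of growth), are three compounds:

Compound 1 `COc1ccccc1/C=C(/SCc1ccc(Cl)c(Cl)c1)C(=O)c1ccc(Cl)cc1` gives 10000 nM
Compound 2 `COc1ccccc1/C=C(/SCc1ccc(F)cc1)C(=O)c1ccc(Cl)cc1` gives 10000 nM
Compound 3 `COc1ccccc1/C=C(/SCc1ccc(C)cc1)C(=O)c1ccc(Cl)cc1` gives 10000 nM

Level with compound 1 and compound 2, compound 3 stands at 10000 nM in this series, so the numbers show no separation among the three. Compound 4 `COc1ccccc1/C=C(/SCc1ccccc1F)C(=O)c1ccc(Cl)cc1` differs from compound 3 by a single change (2-fluorophenyl in place of 4-methylphenyl on a saturated chain carbon bound to a sulfur), made on a saturated chain carbon bound to a sulfur.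

Two measured swaps at that same place bear most directly on this change, and neither moved the value (no change at the digits printed from compound 1 to compound 2 (within the scatter)) and (no change at the digits printed from compound 1 to compound 3 (within the scatter)). The exchange of methyl in place of fluoro on an aromatic carbon was just as flat (no change at the digits printed from compound 2 to compound 3 (within the scatter)). None of the three compounds carries the 2-fluorophenyl group, so the data do not test it directly, and a surprise cannot be ruled out. Still, every step seen so far at this place is null, so no step beyond the scatter is expected (no change at the digits printed from compound 3 to compound 4 (within the scatter)). Compound 4 is estimated at 10000 nM in this assay as the expected value (expected range 4000 nM to 15000 nM).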

Compound 4, concentration for 50% growth inhibition: 10000 nM
The estimate for compound 4 equals the measured number at the digits printed; low and high end bracket the measured number.
By their numbers in this assay, from the lowest: compounds 1, 2, 3 and 4 (each within the scatter of the next).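

In this assay, the 2-fluorophenyl group on a saturated chain carbon bound to a sulfur falls in with the three groups seen earlier, with no change at the digits printed from compound 3 to compound 4 (within the scatter), no change at the digits printed from compound 2 to compound 4 (within the scatter) and no change at the digits printed from compound 1 to compound 4 (within the scatter). The comparison with the 4-fluorophenyl group is the informative new one: both groups hold the same atoms, yet the two compounds remain level, so this pair adds an isomeric change to the swaps of differently substituted phenyl groups that had already proved flat. The series now covers four substituted phenyl groups at this place with no separation among them, though no supporting measurement speaks to why the values stay level.

As far as these compounds go, all four compounds keep a substituted phenyl ring on that chain carbon and share the rest of the core, so it remains open whether a group of another kind at this place, such as an amine, a carboxylic acid or a longer chain, would separate from them. From the compounds shown here alone, it is equally open whether a change elsewhere on the shared core would move the value, or whether any of these phenyl groups would then differ from the others.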